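Ortho Methyl on the Benzyl Ether: Expected Potency

The compounds below may be only part of what the source reports. "The series", "measured", "known", "first", "only" and "open" are said of these compounds alone.

The series shares one core, shown in compound 1 `COc1cccc(OC)c1OCCNCCOc1ccccc1OCc1ccccc1`. In an assay on CHO cells for displacement of a labelled ligand from Alpha-1B adrenergic receptor (Homo sapiens) (a higher number here means a weaker inhibitor, a lower number a stronger inhibitor), compound 1 gives 0.537 nM, the second highest of the three numbers recorded. Compound 2 `COc1cccc(OC)c1OCCNCCOc1ccccc1OCc1ccccc1Cl`, with its 2-chlorophenyl group, gives 0.562 nM in this assay, and compound 3 `COc1cccc(OC)c1OCCNCCOc1ccccc1OCc1cccc(Cl)c1` gives 0.159 nM. The chloro step a 1.0-fold higher number from compound 1 to compound 2 (0.02 log units; within the scatter) stays within the scatter, whereas the chloro step a 3.4-fold lower number from compound 1 to compound 3 (0.53 log units; beyond the scatter) is a modest gain, and the swap a 3.5-fold lower number from compound 2 to compound 3 (0.55 log units; beyond the scatter) echoes that contrast.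

Compound 4 `COc1cccc(OC)c1OCCNCCOc1ccccc1OCc1ccccc1C` differs from compound 1 by methyl in place of hydrogen on an aromatic carbon. Going by the values given here, the step that bears on it most closely is the one from compound 1 to compound 2, where a chloro at the same kind of position changed nothing beyond the scatter; the gain seen with compound 3 sits elsewhere on the ring and does not carry over. A step of about a 1.0-fold higher number from compound 1 to compound 4 (0.01 log units; within the scatter) in this assay is therefore expected, essentially none beyond the scatter. Compound 4 is estimated at 0.55 nM, within a range from 0.22 nM to 1.4 nM.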

Compound 4, inhibition constant: 0.794 nM
Compound 4: middle estimate off by 1.4-fold (0.16 log units), on the low side, within the range that was stated.
By their numbers in this assay, from the lowest: compound 3; then compounds 1, 2 and 4 (each within the scatter of the next).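

Methyl on an aromatic carbon ortho to a large group leaves the number in this assay within the scatter: the step is a 1.5-fold higher number from compound 1 to compound 4 (0.17 log units; within the scatter), and methyl in place of chloro gives a 1.4-fold higher number from compound 2 to compound 4 (0.15 log units; within the scatter). Two different groups at this place, chloro and methyl, have now produced no step beyond the scatter from the unsubstituted benzyl ether. The 3-chlorophenyl group remains apart, since 2-methylphenyl in its place gives a 5.0-fold higher number from compound 3 to compound 4 (0.70 log units; beyond the scatter).

As far as these compounds go, it remains open whether a methyl on the carbon that carries chloro in compound 3 would match that chloro, and whether a methoxy or a trifluoromethyl group would move the number at either place. Nothing at hand bears on why the numbers fall as they do.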